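A few compounds are considered here, and "the series" means these few. Any claim that something is new, unique, unknown or untested is made for them only; others in the source may bear on it.

Of the compounds shown here, three have so far been tested in a functional assay on SF-539 cells (Homo sapiens) for inhibition, read by sulforhodamine B assay, with a stated time of 48 h; on this read-out higher numbers stand for weaker inhibition of growth and lower numbers for stronger inhibition of growth. Compound 1 `COc1cc(-c2nn(-c3cccc(NC(=O)Nc4cc(C(F)(F)F)cc(C(F)(F)F)c4)c3)cc2-c2ccncc2)ccc1Cl` gives 1710 nM in this assay. Compound 2 `COc1cc(-c2nn(-c3cccc(NC(=O)c4cccc(C(F)(F)F)c4)c3)cc2-c2ccncc2)ccc1Cl` gives 2300 nM in this assay. Compound 3 `O=C(Nc1cccc(-n2cc(-c3ccncc3)c(-c3ccc(Cl)c(O)c3)n2)c1)Nc1ccc(Cl)c(Cl)c1` gives 8970 nM in this assay. Of these three numbers, compound 2 has the second highest. Compound 1 lies closest to it, and the two numbers sit within the usual scatter of each other, so nothing separates them. Compound 3 gives the higher number, and that gap lies beyond the scatter.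

Compound 4 `COc1cc(-c2nn(-c3cccc(NC(=O)c4ccc(Cl)c(C(F)(F)F)c4)c3)cc2-c2ccncc2)ccc1Cl` has not yet been measured. It differs from compound 2 in one place: chloro in place of hydrogen on an aromatic carbon. Among the measured compounds shown here, no pair of measured compounds differs in exactly one place, so there is no measured single change to guide the size of this step. The change adds one chlorine to the outer ring and leaves the rest of compound 2 untouched. The step from compound 2 to compound 4 in this assay is expected to be small, a 1.2-fold lower number from compound 2 to compound 4 (0.06 log units; within the scatter), not clearly beyond the scatter in either direction. Compound 4 is therefore expected to give about 2000 nM in this assay, within a range from 900 nM to 4500 nM.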

Compound 4, concentration for total growth inhibition: 20300 nM
Estimate against measurement, compound 4: 10-fold (1.01 log units) below; the whole stated range lies below it.
By their numbers in this assay, from the lowest: compounds 1 and 2 (each within the scatter of the next); then compound 3; then compound 4.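

In this assay the change from 3-(trifluoromethyl)phenyl to 4-chloro-3-(trifluoromethyl)phenyl gives an 8.8-fold higher number from compound 2 to compound 4 (0.95 log units; beyond the scatter) and so clearly weaker inhibition of growth. Among the compounds shown here, this is the first step that changes only one place, and it shows that the ring position ortho to a trifluoromethyl group and para to a large group is not free to change: here, a chloro in place of hydrogen adds just 1 heavy atom, yet moves the number well beyond the scatter. No measurement at hand accounts for the size of this step.

Whether the loss belongs to chloro alone or would follow other groups at this position stays open, as fluoro, methyl, methoxy and an amine are not among the compounds shown. On these data alone, whether the same chloro would cost as much elsewhere also remains unknown.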